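The source may hold more compounds than are shown below. What is called first, only, known or untested is meant among the compounds shown, and "the series" means these compounds.

Measured compounds:
Compound 1 `NC(=O)C1CCN(c2c(S(=O)(=O)c3ccccc3)cnc3ccccc23)CC1`: "not determined" (no result reported)
Compound 2 `O=S(=O)(c1cccc(Cl)c1)c1cnc2cc(Cl)ccc2c1N1CCC(CO)CC1`: 30.9 nM
Compound 3 `CC1CCN(c2c(S(=O)(=O)c3ccc(Cl)cc3)cnc3ccc(Cl)cc23)CC1`: 435 nM

Compound 1 carries a carbamoyl group on its piperidine ring and no chlorine on either aryl part; on the numbers shown it stands nowhere, since in this assay compound 1 has no result reported. The two compounds with results share a chlorinated core and a chlorinated phenylsulfonyl group and differ from each other in more than one place, so their gap, which lies beyond the usual scatter, is not assigned to a single change.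

Compound 4 `O=S(=O)(c1ccccc1)c1cnc2ccccc2c1N1CCCCC1` is the unmeasured partner of compound 1. The difference between them is hydrogen in place of carbamoyl on a saturated ring carbon. For the measured compounds named here, in an assay on isolated protein for displacement of a labelled ligand from metabotropic glutamate receptor 5 (Homo sapiens), with a stated time of 60 min (on this read-out higher numbers stand for weaker inhibition and lower numbers for stronger inhibition), compound 1 is recorded as "not determined" (no result reported), so no step can be sized here; the account can only note that compound 4 keeps the bare piperidine and lacks every chlorine found in compound 2 and compound 3.

Compound 4 is estimated to give 1200 nM in this assay, with an expected range from 200 nM to 6000 nM.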

Compound 4, inhibition constant: 307 nM
Compound 4: the middle estimate sits 3.9-fold (0.59 log units) above what was measured; measured number inside the range.
By their numbers in this assay, from the lowest: compound 2; then compounds 4 and 3 (each within the scatter of the next).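

In this assay, for the compounds shown here, compound 4 gives 307 nM while compound 1 has no reported result, so no step between compound 1 and compound 4 can be read. No further evidence bears on this result. The compounds shown leave open what the carbamoyl group contributes on this read-out.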